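A few compounds are considered here, and "the series" means these few. Any claim that something is new, unique, unknown or untested is made for them only; others in the source may bear on it.

In a functional assay on LOX IMVI cells (Homo sapiens) for cytotoxicity, read by MTT assay, with a stated time of 24 h (on this read-out higher numbers stand for weaker inhibition and lower numbers for stronger inhibition), compound 1 `COc1cc(-c2nc(-c3ccccc3)[nH]c2-c2ccnc(NCCCNS(=O)(=O)c3ccccc3)n2)ccc1F` gives 4520 nM, and compound 2 `COc1cc(-c2nc(-c3ccccc3)[nH]c2-c2ccnc(NCCCNS(=O)(=O)c3ccc(Br)cc3)n2)ccc1F` gives 33900 nM. Among the measured compounds shown here, compound 2 therefore has the highest of the two numbers so far, which means the weaker inhibition. For the measured compounds named here, the one measured step is a 7.5-fold higher number from compound 1 to compound 2 (0.88 log units; beyond the scatter), and it came from bromo in place of hydrogen on an aromatic carbon.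

The next compound is compound 3 `COc1cc(-c2nc(-c3ccccc3)[nH]c2-c2ccnc(NCCCNS(=O)(=O)c3ccc(C)cc3)n2)ccc1F`. It differs from compound 2 by methyl in place of bromo on an aromatic carbon, turning the 4-bromophenyl into 4-methylphenyl. Going by the values given here, this is the same ring position that changed in the measured step, so that step is the only guide, and no methyl compound has been measured yet. Compound 3 gives up the bromo that went with a 7.5-fold higher number from compound 1 to compound 2 (0.88 log units; beyond the scatter) but does not return to hydrogen. A partial move back is therefore expected, towards a lower number, and smaller than the measured step. The expected step is a 3.1-fold lower number from compound 2 to compound 3 (0.49 log units; beyond the scatter). Compound 3 is estimated at 11000 nM, with an expected range of 3500 nM to 30000 nM.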

Compound 3, half-maximal inhibitory concentration: 2590 nM
Beside the measured number, compound 3's estimate is 4.2-fold (0.63 log units) above it, and the stated range ends above it.
By their numbers in this assay, from the lowest: compounds 3 and 1 (each within the scatter of the next); then compound 2.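

Among the compounds shown here, the bromo in compound 2 now looks like the exception at this ring carbon, para to a large group, rather than the first step in a trend. In this assay, replacing it with methyl gives a 13-fold lower number from compound 2 to compound 3 (1.12 log units; beyond the scatter), while putting methyl in place of the hydrogen gives a 1.7-fold lower number from compound 1 to compound 3 (0.24 log units; within the scatter), which is within the scatter, so methyl and hydrogen cannot be told apart here. Bromo and methyl each count as one heavy atom, with no ring, no hydrogen-bond donors or acceptors and no net charge, so these counts do not separate the two groups, and no measurement at hand explains why the bromo compound gives the higher number.

With only hydrogen, bromo and methyl shown at this carbon, it remains open whether the higher number belongs to bromo alone or would also appear with groups such as chloro, methoxy, an amine or a carboxylic acid. As far as these compounds go, it is also open whether the same swap would give a similar step at another carbon of this ring, or on a longer chain linking the sulfonyl group to the shared core.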